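This account rests on a few compounds, and the source may have more. Where it says the series, first, only, none or still open, it means among the compounds named here.

Compound 1 `COc1ccc2sc(NC(=O)c3ccc(C)cc3)nc2c1` belongs to a small set of amides built on one shared core. In a functional assay on MDA-MB-231 cells (Homo sapiens) for antiproliferative activity, read by sulforhodamine B assay (a higher number here means a weaker inhibitor of growth, a lower number a stronger inhibitor of growth), compound 1 reaches only the limit of the assay, > 10 ug/mL, and gives no number. Compound 3 `COc1cccc2sc(NC(=O)c3ccc(C#N)cc3)nc12`, which carries a cyano group and a differently placed methoxy, likewise stops at the limit in this assay with > 10 ug/mL. For the measured compounds named here, compound 2 `Cc1cc(C)c2sc(NC(=O)c3ccc(C#N)cc3)nc2c1`, also with a cyano group but on a dimethyl core, gives 0.48 ug/mL in this assay, the only numeric value of the three. The other two sit at the limit of > 10 ug/mL in this assay, at which 2 of the 3 values shown sit. Compound 4 `COc1ccc2sc(NC(=O)c3ccc(C#N)cc3)nc2c1` has not yet been tested. It differs from compound 1 by cyano in place of methyl on an aromatic carbon. Compound 2 shows that a cyano group can go with measurable growth inhibition, while compound 3 shows it does not do so on every core, so the direction is uncertain. Compound 4 is estimated at 3 ug/mL, within 0.5 ug/mL to 10 ug/mL. The step of an at least 3.3-fold lower number from compound 1 to compound 4 (0.52 log units; beyond the scatter) is expected to go toward stronger inhibition, though a result at the limit again would not surprise.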

Compound 4, concentration for 50% growth inhibition: > 10 ug/mL
Compound 4 ended at the assay's limit; the forecaster's own chance of this, stated with the estimate: 40%; middle value at least 3.3-fold (0.52 log units) from the limit.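

Compound 1 and compound 4 both stop at the limit of the assay, so no step between them can be read: the limit of > 10 ug/mL in this assay, at which 3 of the 4 values shown sit.

Still open, going by these compounds, is whether cyano in place of methyl on the shared core changes growth inhibition at all in this assay, where compound 2 alone gives a number.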